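The compounds below may be only part of what the source reports. "The series", "measured", "known", "first", "only" and "open" are said of these compounds alone.

Working notes on the sulfonamide series in a functional assay on MCF7 cells (Homo sapiens) for inhibition, read by sulforhodamine B assay, with a stated time of 24 h; a lower number here means a stronger inhibitor, a higher number a weaker inhibitor.

Of the compounds shown here, three carry numbers so far. Compound 1 `N#Cc1c(-c2ccccc2)cn(-c2ccc(S(=O)(=O)Nc3nccs3)cc2)c1NC(N)=O` gives 8050 nM. Compound 2 `CC(=O)Nc1c(C#N)c(-c2ccccc2)cn1-c1ccc(S(=O)(=O)Nc2ccccn2)cc1` gives 11800 nM. Compound 3 `Nc1nc(=O)[nH]c2c1c(-c1ccccc1)cn2-c1ccc(S(=O)(=O)Nc2nccs2)cc1` gives 8320 nM. Among these three, compound 3 stands second highest; its nearest neighbour is compound 1, whose number lies within the scatter of that of compound 3, and its furthest is compound 2, whose number is also within the scatter of that of compound 3. For the measured compounds named here, no pair of measured compounds differs in a single place, so no step within the measured set can be read off; compound 1 and compound 2 share the change at the sulfonamide nitrogen with a second change elsewhere, and their two numbers simply lie close together.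

Compound 4 `Nc1nc(=O)[nH]c2c1c(-c1ccccc1)cn2-c1ccc(S(=O)(=O)Nc2ccccn2)cc1` is the next member, not yet measured. It differs from compound 3 only at the sulfonamide nitrogen: pyridin-2-yl in place of 1,3-thiazol-2-yl on a sulfonamide nitrogen. Because compound 1 with 8050 nM and compound 2 with 11800 nM sit close together, no step beyond the scatter is expected from compound 3 to compound 4 in this assay, in either direction. For compound 4 the estimate is 9500 nM, with a range from 4000 nM to 22000 nM, which corresponds to an expected step of a 1.1-fold higher number from compound 3 to compound 4 (0.06 log units; within the scatter).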

Compound 4, half-maximal inhibitory concentration: 3900 nM
Estimate against measurement, compound 4: 2.4-fold (0.39 log units) above; the measured number lies below the stated range.
By their numbers in this assay, from the lowest: compound 4; then compounds 1, 3 and 2 (each within the scatter of the next).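

In this assay the sulfonamide nitrogen proves to be a place where the group carried on the core of compound 3 moves the number: pyridin-2-yl in place of 1,3-thiazol-2-yl gives a 2.1-fold lower number from compound 3 to compound 4 (0.33 log units; beyond the scatter), a modest step, but the only one so far that can be read and it lies beyond the scatter. The earlier compounds shown here could not show this, since no two of them differ in one place, and the close numbers of compound 1 and compound 2 cannot be read as a statement about this change alone, so no other step can be read. Nothing at hand bears on why the step occurs, and it rests on a single pair on a single core.

Whether the same change gives a step of similar size on the core of compound 1 stays open, since the compounds shown hold no pair on that core that differs only at the sulfonamide nitrogen. Also open, as far as these compounds go, is how far the number moves with other groups in this place, such as a pyrimidin-2-yl ring, a simple methyl group or a plain phenyl ring.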